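A Chlorophenyl Replaces Indolyl on the Amine Nitrogen

The source may hold more compounds than are shown below. What is called first, only, known or untested is meant among the compounds shown, and "the series" means these compounds.

Compound 1 `COc1ccc(N/C=C\C(=O)c2nc(-c3ccc(C(F)(F)F)cc3)n3ccccc23)cc1OC` gives > 30000 nM in a functional assay on B16-F10 cells (Mus musculus) for cytotoxicity, read by MTT assay, with a stated time of 48 h; a lower number here means a stronger inhibitor, a higher number a weaker inhibitor; for compound 1 that value is a limit of the assay. Compound 2 `COc1ccc(-c2nc(C(=O)/C=C\Nc3ccc(Cl)cc3)c3ccccn23)cc1` gives 1240 nM in this assay. Compound 3 `O=C(/C=C\Nc1ccc2[nH]ccc2c1)c1nc(-c2ccc(C(F)(F)F)cc2)n2ccccc12` gives 18200 nM in this assay.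

Compound 3 thus holds the highest of the two numbers, with compound 2 a long way lower and compound 1 yielding only a limit. Compound 4 `O=C(/C=C\Nc1ccc(Cl)cc1)c1nc(-c2ccc(C(F)(F)F)cc2)n2ccccc12` is compound 3 with 4-chlorophenyl in place of 1H-indol-5-yl on an amine nitrogen. Among the compounds with values here, the only measured step on that same nitrogen, an at least 1.6-fold lower number from compound 1 to compound 3 (0.21 log units; that floor lies within the scatter), starts from a limit and so fixes only a floor. Compound 2 already carries the 4-chlorophenyl on the amine nitrogen, though it differs from compound 4 elsewhere too. Compound 4 is therefore expected to give a lower number, by a 3.6-fold lower number from compound 3 to compound 4 (0.56 log units; beyond the scatter), estimated at 5000 nM within 1500 nM to 16000 nM.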

Compound 4, half-maximal inhibitory concentration: > 30000 nM
Compound 4 ended at the assay's limit; the forecaster's own chance of this, stated with the estimate: 10%; middle value at least 6.0-fold (0.77 log units) away from the limit.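

Compound 4 gives > 30000 nM in this assay, and this is a limit of the assay. With trifluoromethyl on the aromatic carbon, 4-chlorophenyl on the amine nitrogen gave no lower number, though an at least 1.6-fold higher number from compound 3 to compound 4 (0.21 log units; that floor lies within the scatter) is only a floor. With 4-chlorophenyl held fixed, trifluoromethyl in place of methoxy makes a large difference, an at least 24-fold higher number from compound 2 to compound 4 (1.38 log units; beyond the scatter). The step between the two compounds at the limit cannot be read: the limit of > 30000 nM in this assay, at which 2 of the 4 values shown sit.

Going by these compounds, whether a nitrile or an ethoxy group on that aromatic carbon would keep the lower number of compound 2 remains open.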